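A few compounds are considered here, and "the series" means these few. Any claim that something is new, unique, unknown or untested is made for them only; others in the source may bear on it.

Of the compounds shown here, three built on one shared core have been measured in an ADME assay (liver) for metabolic stability, with Liver microsome (Rattus norvegicus) as the target, using microsomes; a higher number here means faster removal of the compound, a lower number slower removal. Compound 1 `Cc1cc(C(=O)N2CCC(Oc3ccc4c(c3)CCN(C3CCC3)CC4)CC2)no1` gives 3.5 mL.min-1.g-1, compound 2 `O=C(N1CCOCC1)N1CCC(Oc2ccc3c(c2)CCN(C2CCC2)CC3)CC1` gives 1.1 mL.min-1.g-1, and compound 3 `Cn1c(=O)ccc2cc(COc3ccc4c(c3)CCN(C3CCC3)CC4)ccc21` gives 2.5 mL.min-1.g-1. Compound 2 thus has the lowest number of the three, with compound 3 nearer to it and compound 1 further away. Within the data shown here, the only step between close neighbours is a 3.2-fold lower number from compound 1 to compound 2 (0.50 log units; beyond the scatter), a modest drop when morpholin-4-yl replaced 5-methyl-1,2-oxazol-3-yl on a carbonyl carbon. Compound 4 `O=C(c1ccc(Cl)cc1)N1CCC(Oc2ccc3c(c2)CCN(C2CCC2)CC3)CC1` reverses that kind of change: 4-chlorophenyl in place of morpholin-4-yl on a carbonyl carbon. A rise in this assay is expected because compound 1 gives 3.5 mL.min-1.g-1 with an aromatic ring on the same carbonyl carbon. Compound 4 is therefore estimated at 3.5 mL.min-1.g-1, between 1.5 mL.min-1.g-1 and 8 mL.min-1.g-1, an expected step of a 3.2-fold higher number from compound 2 to compound 4 (0.50 log units; beyond the scatter).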

Compound 4, intrinsic clearance in microsomes: 2.9 mL.min-1.g-1
Compound 4: the middle estimate sits 1.2-fold (0.08 log units) above what was measured, and the stated range covers the measured number.
By their numbers in this assay, from the lowest: compound 2; then compounds 3, 4 and 1 (each within the scatter of the next).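

Putting 4-chlorophenyl in place of morpholin-4-yl on the carbonyl carbon gives a 2.6-fold higher number from compound 2 to compound 4 (0.42 log units; beyond the scatter) in this assay, so a carbon-only aromatic ring also stands above morpholin-4-yl, as 5-methyl-1,2-oxazol-3-yl does. Exchanging those two aromatic groups gives only a 1.2-fold lower number from compound 1 to compound 4 (0.08 log units; within the scatter) and so does not separate them in this assay. Nothing available explains why morpholin-4-yl gives the lower number. From the compounds shown here alone, whether piperidin-1-yl or dimethylamino on the same carbonyl carbon would also give a low number remains open. So does whether plain phenyl would match 4-chlorophenyl.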